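Ethyl for tert-butyl on the fused core

This account rests on a few compounds, and the source may have more. Where it says the series, first, only, none or still open, it means among the compounds named here.

Compound 1, `Cc1nc(Cc2ccccc2)n2c(O)nncc12`, in a functional assay for inhibition, with Homo sapiens as the target (on this read-out higher numbers stand for weaker inhibition and lower numbers for stronger inhibition), gives > 48000 nM, a limit of the assay.
Compound 2, `CCc1nc(C)c2cnnc(SC)n12`, in this assay gives > 48000 nM, also a limit of the assay.
Compound 3, `Cc1nc(C(C)(C)C)n2c(O)nncc12`, in this assay gives 31000 nM.

Going by the values given here, compound 3 holds the only numerical value in the set; the two other entries are limits, as noted in the limit of > 48000 nM in this assay, at which 2 of the 3 values shown sit. Among the compounds with values here, no pair of measured compounds differs in a single place, so no measured step is available for comparison.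

Compound 4, `CCc1nc(C)c2cnnc(O)n12`, is not yet measured. It differs from compound 3 by ethyl in place of tert-butyl on an aromatic carbon. Compound 2 carries the same ethyl group together with a methylthio group and sits at the limit, whereas compound 3 with tert-butyl gives a number, so the smaller chain is not expected to improve inhibition. In this assay the step from compound 3 to compound 4 is expected to be a 1.5-fold higher number from compound 3 to compound 4 (0.16 log units; within the scatter), a loss that may not exceed the scatter. Compound 4 is therefore estimated at 45000 nM, within 18000 nM to 110000 nM, with a fair chance that only a limit is reported.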

Compound 4, half-maximal inhibitory concentration: > 48000 nM
Compound 4 was reported as a limit; the forecaster's own chance of this, stated with the estimate: 55%; middle value at least 1.0-fold (0.02 log units) from the limit.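

On the aromatic carbon between two ring nitrogen atoms, a single-place comparison now exists: in this assay, ethyl in place of tert-butyl gives an at least 1.5-fold higher number from compound 3 to compound 4 (0.18 log units; that floor lies within the scatter). Going by these compounds alone, that step is only a floor, so it does not separate ethyl from tert-butyl beyond the scatter, and its true size remains unknown, while compound 3 is still the only compound with a number rather than a limit. The steps to compound 4 from compound 1 and from compound 2 cannot be read, and most of the set now rests on a single limit: the limit of > 48000 nM in this assay, at which 3 of the 4 values shown sit.

On these data alone, whether the number for compound 3 depends on tert-butyl itself remains open, as does whether a propyl chain or a cyclohexyl ring on this carbon would give a number. As far as these compounds go, an amine on this carbon is equally open.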